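A few compounds are considered here, and "the series" means these few. Any claim that something is new, unique, unknown or untested is made for them only; others in the source may bear on it.

Compound 1 `COc1cccc(/C=C/C(=O)c2ccc(OC)c3c2OC(C)(C)C=C3)c1`: in a functional assay on SW-620 cells (Homo sapiens) for antiproliferative activity, read by MTT assay, with a stated time of 24 h (on this read-out lower numbers stand for stronger inhibition and higher numbers for weaker inhibition), compound 1 gives > 10000 nM, which is a limit of the assay rather than a number.
Compound 2 `COc1ccc(C(=O)/C=C/c2ccc([N+](=O)[O-])cc2)c2c1C=CC(C)(C)O2`: in this assay compound 2 gives 3520 nM.
Compound 3 `COc1ccc(C(=O)/C=C/c2ccccc2)c2c1C=CC(C)(C)O2`: in this assay compound 3 gives > 10000 nM, again a limit rather than a number.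

Compound 3 thus stands at the limit of this assay, and it shares that position with one other compound (the limit of > 10000 nM in this assay, at which 2 of the 3 values shown sit). Among the compounds with values here, the one readable step that reaches it is an at least 2.8-fold higher number from compound 2 to compound 3 (0.45 log units; beyond the scatter), a step of at least modest size toward weaker inhibition. The other, a step that the two limits leave unreadable from compound 1 to compound 3, has limits at both ends and its size cannot be read.

Compound 4 `COc1ccc(C(=O)/C=C/c2ccco2)c2c1C=CC(C)(C)O2` differs from compound 3 by furan-2-yl in place of phenyl on a double-bonded chain carbon bound to a double-bonded chain carbon. Within the data shown here, none of the measured steps covers an exchange of one ring for another at this place; the only step that alters that end of the chain, an at least 2.8-fold lower number from compound 1 to compound 2 (0.45 log units; beyond the scatter), concerns substituents on a phenyl ring, not the ring itself. Among the measured compounds shown here, with compound 3 at a limit and no step to lean on, compound 4 is expected to stay close to where compound 3 lies, the estimated step being an at least 1.2-fold lower number from compound 3 to compound 4 (0.09 log units; that floor lies within the scatter). Compound 4 is therefore estimated at 8000 nM, with a range from 2000 nM to 30000 nM.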

Compound 4, half-maximal inhibitory concentration: > 10000 nM
Compound 4 gave a limit, no number (the forecaster's own chance of this, stated with the estimate: 55%); middle value at least 1.2-fold (0.09 log units) from the limit.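

At this place on a double-bonded chain carbon, the set now includes an exchange of one ring for another: furan-2-yl, a five-membered aromatic ring with one oxygen, in place of phenyl. In this assay compound 4 gives > 10000 nM, which is a limit of the assay and not a number. The only readable step is an at least 2.8-fold higher number from compound 2 to compound 4 (0.45 log units; beyond the scatter), which leaves 4-nitrophenyl as the only group shown at this place that gives a number, while furan-2-yl joins phenyl and 3-methoxyphenyl at the limit: the limit of > 10000 nM in this assay, at which 3 of the 4 values shown sit.

On these data alone, the steps to compound 4 from compound 3 and from compound 1 have limits at both ends and cannot be read, so it stays open whether furan-2-yl differs at all from phenyl or 3-methoxyphenyl in this assay. Also open, as far as these compounds go, is whether a number would appear with another ring at this place, such as thiophen-2-yl or pyridin-3-yl, or with a furan ring carrying a nitro group, or with a phenyl ring carrying an amine or a carboxylic acid.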